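Ester Removal on Two Related Cores Against Scenedesmus

The source may hold more compounds than are shown below. What is called first, only, known or untested is meant among the compounds shown, and "the series" means these compounds.

Measured compounds:
compound 1 `O=C1C2=C(CCCC2)S(=O)(=O)N1c1ccc(Cl)cc1`: 8510 nM
compound 2 `CC(C)OC(=O)c1cc(N2C(=O)C3=C(CCCC3)S2(=O)=O)ccc1Cl`: 832 nM
compound 3 `CC(C)OC(=O)c1cc(-n2c(=O)c3c([s+]2[O-])CCCC3)ccc1Cl`: 51300 nM

All three were tested in a functional assay on the whole organism for inhibition, with Scenedesmus acutus as the target, with a stated time of 20 min; on this read-out higher numbers stand for weaker inhibition and lower numbers for stronger inhibition. Compound 2 gives the lowest number, and compound 1, which differs from it by hydrogen in place of isopropoxycarbonyl on an aromatic carbon, gives a clearly higher one: the step of a 10-fold higher number from compound 2 to compound 1 (1.01 log units; beyond the scatter). Compound 3 carries the same isopropoxycarbonyl group and chloro group as compound 2 but on a different core; how the two cores differ is not broken down here. In this assay compound 3 gives the highest number of the three, and its distance to compound 1 and to compound 2 lies beyond the scatter, so it is the weakest inhibitor of the measured set.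

Compound 4 `O=c1c2c([s+]([O-])n1-c1ccc(Cl)cc1)CCCC2` has not yet been measured. It differs from compound 3 by hydrogen in place of isopropoxycarbonyl on an aromatic carbon, at a place described in the same words as for the pair compound 2 and compound 1, so this is the same change made on the other core. Compound 4 is therefore expected to follow the earlier step: an estimated step of a 5.8-fold higher number from compound 3 to compound 4 (0.77 log units; beyond the scatter), resting on the step of a 10-fold higher number from compound 2 to compound 1 (1.01 log units; beyond the scatter) and on the value of compound 3, 51300 nM. Since compound 3 already gives a high number, the assay may well report only a limit for compound 4. The estimate for compound 4 in this assay is 300000 nM, with a likely range from 80000 nM to 1500000 nM.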

Compound 4, half-maximal inhibitory concentration: 30200 nM
For compound 4 the middle estimate is 9.9-fold (1.00 log units) above the measured one; measured number outside the range, below it.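

In this assay, replacing the isopropoxycarbonyl group with hydrogen does not do the same thing on the two cores, as the two steps set side by side show: the same change on two cores in this assay, a 10-fold higher number (1.01 log units; beyond the scatter) from compound 2 to compound 1 and a 1.7-fold lower number (0.23 log units; within the scatter) from compound 3 to compound 4, 17-fold (1.24 log units) apart, beyond the scatter of two such steps. On the core of compound 3, the new step, a 1.7-fold lower number from compound 3 to compound 4 (0.23 log units; within the scatter), stays within the usual scatter, so this swap leaves no readable mark there, whereas on the core of compound 2 the same swap clearly gave a higher number. Among the compounds shown here, the effect of this change therefore cannot simply be carried from one core to the other, but with only one pair on each core, the data show that the two cores differ here and not why they differ or how any other change would behave on them.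

The compounds shown leave open whether the gap between the two cores would persist with other groups on the same aromatic carbon, such as a carboxylic acid, a methyl ester or a longer ester chain in place of isopropoxycarbonyl. They also leave open whether replacing the chloro group with another group, such as fluoro or methoxy, would alter the picture on either core.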